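A Second Methoxy on the Fused Ring of Compound 3

The source may hold more compounds than are shown below. What is called first, only, known or untested is meant among the compounds shown, and "the series" means these compounds.

Of the compounds shown here, three built on one shared core have been measured in an assay on isolated protein for binding affinity to 5-hydroxytryptamine receptor 1B (Rattus norvegicus); on this read-out lower numbers stand for stronger inhibition and higher numbers for weaker inhibition. Compound 1 `c1ccc2c(c1)CC(CN1CCN(c3cccc4c3OCCO4)CC1)C2` gives 490 nM in this assay. Compound 2 `C1=C(CCN2CCN(c3cccc4c3OCCO4)CC2)Cc2ccccc21` gives 933 nM in this assay. Compound 3 `COc1ccc2c(c1)C(CCN1CCN(c3cccc4c3OCCO4)CC1)C2` gives 316 nM in this assay. Compound 3 has the smallest of these numbers, yet its gap to compound 1 falls within the usual scatter, so no order between those two can be drawn; only compound 2 lies beyond the scatter, with a higher number. Compound 4 `COc1cc2c(cc1OC)C(CCN1CCN(c3cccc4c3OCCO4)CC1)C2` differs from compound 3 by methoxy in place of hydrogen on an aromatic carbon. Among the measured compounds shown here, no measured pair shows the effect of such a change here. The expected step is a 1.0-fold higher number from compound 3 to compound 4 (0.01 log units; within the scatter) in this assay, nothing beyond the scatter. Compound 4 is estimated at 320 nM, within a range from 110 nM to 950 nM.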

Compound 4, inhibition constant: 794 nM
For compound 4 the middle estimate is 2.5-fold (0.39 log units) below the measured one, within the range that was stated.
By their numbers in this assay, from the lowest: compounds 3, 1, 4 and 2 (each within the scatter of the next, the first and the last beyond it).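

In this assay, methoxy in place of hydrogen on this aromatic carbon, ortho to a methoxy group, brings a 2.5-fold higher number from compound 3 to compound 4 (0.40 log units; beyond the scatter), so this change at this position is not silent on the shared core. It is the first single-place step among these compounds that can be read. No available evidence accounts for its size. From the compounds shown here alone, whether a hydroxyl or a fluorine on this carbon would leave the number nearer that of compound 3 or of compound 4 stays open, as does whether methoxy here would bring a similar step without the ortho methoxy group.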